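Clearance Expected After Swapping an Amide for a Thiophene

This account rests on a few compounds, and the source may have more. Where it says the series, first, only, none or still open, it means among the compounds named here.

Measured compounds:
Compound 1, `CN(C)C(=O)CN1CCC(c2cc3c(-c4ccc(=O)n(C5CCC5)c4)ccnc3[nH]2)CC1`: in an ADME assay on cells (Hepatocyte, Homo sapiens) for metabolic stability (on this read-out lower numbers stand for slow clearance and higher numbers for fast clearance), compound 1 gives < 1 uL/min, which is a limit of the assay rather than a number.
Compound 2, `CC(C)n1cc(-c2ccnc3[nH]c(C4CCN(CC(=O)N5CCCCC5)CC4)cc23)ccc1=O`: in this assay compound 2 gives 8 uL/min.

Among the compounds with values here, compound 2 holds the only numerical reading in this assay among the two measured compounds. The other measured compound, compound 1, sits at the limit of < 1 uL/min in this assay, at which 1 of the 2 values shown sits, so the readings of compound 1 and compound 2 cannot be compared as a step of known size.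

The account now turns to compound 3, `CC(C)n1cc(-c2ccnc3[nH]c(C4CCN(Cc5cccs5)CC4)cc23)ccc1=O`, which has not yet been measured in this assay. Compared with compound 2, the change is thiophen-2-yl in place of (piperidin-1-yl)carbonyl on a saturated chain carbon bound to an amine nitrogen in a ring. Within the data shown here, no measured pair in this set shares that change, so there is no measured step to lean on. The expectation is that the step from compound 2 to compound 3 in this assay will be a rise, a 2.3-fold higher number from compound 2 to compound 3 (0.35 log units; beyond the scatter), somewhat beyond the usual scatter, though a result within the scatter would not surprise. On that basis compound 3 is estimated at 18 uL/min in this assay, with a range from 6 uL/min to 50 uL/min.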

Compound 3, intrinsic clearance in a liver preparation (reported as CLH), per the amount of preparation that the assay uses: 5.8 uL/min
Beside the measured number, compound 3's estimate is 3.1-fold (0.49 log units) above it; measured number below the stated range.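

In this assay, within the data shown here, the exchange of the amide-bearing group for the aromatic ring reads as a 1.4-fold lower number from compound 2 to compound 3 (0.14 log units; within the scatter), which gives the first measured step at this position on a saturated chain carbon bound to an amine nitrogen in a ring. On this one pair, the (piperidin-1-yl)carbonyl, with its carbonyl and six-membered non-aromatic ring, can give way to the smaller thiophen-2-yl and the reading stays within the scatter, so the two groups cannot be told apart in this assay. Nothing among the data shown accounts for why the two groups read alike.

Among these compounds, compound 1 gives < 1 uL/min in this assay, which is a limit of the assay and not a number, and it differs from compound 2 in more than one place, so no step to it can be read. As far as these compounds go, what stays open is whether a carboxylic acid or a morpholine ring on that same saturated chain carbon would also read like compound 2 and compound 3, as this single pair says nothing about any other group there.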